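The source may hold more compounds than are shown below. What is called first, only, known or untested is meant among the compounds shown, and "the series" means these compounds.

Compound 3 `CC(C)(C)N(NC(=O)c1cccc(Cl)c1)C(=O)c1ccccc1Cl` has the lowest number of the three compounds measured in an assay on cells for agonist activity at ecdysone receptor (Bombyx mori), read by a luciferase reporter, with a stated time of 24 h; a lower number here means that less compound is needed, a higher number that more compound is needed for the effect; compound 3 gives 155 nM, while compound 1 `CC(C)(C)N(NC(=O)c1ccccc1)C(=O)c1ccccc1C(F)(F)F` gives 631 nM and compound 2 `CC(C)(C)N(NC(=O)c1ccccc1I)C(=O)c1ccccc1Cl` gives 1290 nM. Compound 4 `CC(C)(C)N(NC(=O)c1ccc(I)cc1)C(=O)c1ccccc1Cl` differs from compound 3 by 4-iodophenyl in place of 3-chlorophenyl on a carbonyl carbon. Among the measured steps, only the one from compound 2 to compound 3 touches the same carbonyl carbon: an 8.3-fold lower number from compound 2 to compound 3 (0.92 log units; beyond the scatter). Among the measured compounds shown here, no measured pair shows what a 4-iodophenyl does, so the direction of the step to compound 4 rests on little. In this assay compound 4 is expected to give 320 nM, within a range of 80 nM to 1300 nM. That estimate means a step of a 2.1-fold higher number from compound 3 to compound 4 (0.31 log units; beyond the scatter), a modest rise with wide uncertainty.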

Compound 4, half-maximal effective concentration: 7.59 nM
The estimate for compound 4 lay 42-fold (1.62 log units) above the measured number, and the stated range ends above it.
By their numbers in this assay, from the lowest: compound 4; then compound 3; then compound 1; then compound 2.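

Among the compounds shown here, the group on this carbonyl carbon can shift the number much further than the earlier compounds showed: in this assay, 4-iodophenyl in place of 3-chlorophenyl gives a 20-fold lower number from compound 3 to compound 4 (1.31 log units; beyond the scatter). With iodine on both rings, 4-iodophenyl in place of 2-iodophenyl gives a 170-fold lower number from compound 2 to compound 4 (2.23 log units; beyond the scatter), so the position of the iodine alone has a large effect here. Nothing available explains these steps.

Going by these compounds, the first step changes both the halogen and its ring position, so the share of each remains unknown. On these data alone, it also remains open how a 4-chlorophenyl or 4-aminophenyl group would compare.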